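Branching the Alkyl Chain of a Guanidine Compound

A few compounds are considered here, and "the series" means these few. Any claim that something is new, unique, unknown or untested is made for them only; others in the source may bear on it.

Measured so far:
Compound 1, `COCCNC(=N)NCCCCC(=O)O`: 2%
Compound 2, `CCCCCNC(=N)NCCOC`: 21%

Of the compounds shown here, two have been measured in an assay on isolated protein for inhibition of Nitric oxide synthase, inducible (Homo sapiens), read by spectrophotometry, using NADPH, tested at 1 mM, in the presence of a further agent that is not named here; on this read-out lower numbers stand for less inhibition and higher numbers for more inhibition at the one concentration tested (going by the name of the read-out). Compound 1 gives 2%, and compound 2 gives 21%, which is the higher of the two numbers. Within the data shown here, the one step measured, a number 19 percentage points higher from compound 1 to compound 2 (beyond the scatter), is a modest rise that lies beyond the scatter.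

Compound 3 `COCCNC(=N)NCCC(C)C` is the next compound. It differs from compound 2 by isopropyl in place of propyl on a saturated chain carbon, two bonds along the chain from an amine nitrogen. Among the measured compounds shown here, no measured step bears on this change: the only step recorded concerns the exchange of a carboxy for a methyl, not the branching of a chain that keeps all its atoms. The data contain nothing that points to a rise or a fall from this kind of change. With nothing to go on, the expectation is a step of a number 3 percentage points lower from compound 2 to compound 3 (within the scatter), which stays within the scatter. Compound 3 is therefore expected to give about 18% in this assay, with a range from 4% to 34%.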

Compound 3, a percentage reported as inhibition, at one concentration (the size of the read-out at that concentration, not a potency): 4%
Beside the measured number, compound 3's estimate is 14 percentage points above it; measured number inside the range.
By their numbers in this assay, from the lowest: compounds 1 and 3 (each within the scatter of the next); then compound 2.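

Rearranging a chain without adding or removing any atom is enough to move the number in this assay: isopropyl in place of propyl, on a saturated chain carbon two bonds along the chain from an amine nitrogen, gives a number 17 percentage points lower from compound 2 to compound 3 (beyond the scatter). So the read-out responds not only to swapping one group for a different kind of group, as in the earlier step, but also to the shape of a chain made of the same carbons. The 2-carboxyethyl group of compound 1 sits at this same place, and exchanging it for isopropyl gives a number 2 percentage points higher from compound 1 to compound 3 (within the scatter), so these two groups cannot be told apart here, while propyl in compound 2 stands clear of both. Among these compounds, nothing measured so far explains why the branched chain gives the lower number.

From the compounds shown here alone, it remains open whether the fall belongs to branching in general or to isopropyl alone, which a cyclopropyl group or a longer branched chain in place of propyl could help to separate. With only these three compounds, it is also unclear whether a longer straight chain would raise the number further.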